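Carboxyalkyl chain length and Caco-2 permeability in the series

A few compounds are considered here, and "the series" means these few. Any claim that something is new, unique, unknown or untested is made for them only; others in the source may bear on it.

Measured so far:
compound 1, `CCC(C(=O)O)c1nn(Cc2cn3cc(OCC4CC4)c(Cl)cc3n2)c2ccccc2c1=O`: 17 10^-6 cm/s
compound 2, `CC(C(=O)O)c1nn(Cc2cn3cc(OCC4CC4)c(C(F)(F)F)cc3n2)c2ccccc2c1=O`: 15 10^-6 cm/s
compound 3, `O=C(O)Cn1nc(Cc2cn3cc(OCC4CC4)c(Cl)cc3n2)c2ccccc2c1=O`: 0.5 10^-6 cm/s

In an ADME assay on Caco-2 cells (Homo sapiens) for permeability, read by HPLC, in the apical to basolateral direction, with a stated time of 60 min, at pH 6.5, tested at 10 uM (a lower number here means that the compound crosses the layer more slowly, a higher number that the compound crosses the layer faster), compound 1 gives 17 10^-6 cm/s. Compound 2 gives 15 10^-6 cm/s in this assay, a number that sits within the scatter of the value of compound 1, so no order can be read between the two. Compound 3 gives 0.5 10^-6 cm/s in this assay, which lies beyond the scatter below compound 1 and marks the low end of the three numbers. For the measured compounds named here, with three compounds and no pair differing in a single place, no step size is established.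

The next compound, compound 4, `C[C@H](C(=O)O)c1nn(Cc2cn3cc(OCC4CC4)c(Cl)cc3n2)c2ccccc2c1=O`, differs from compound 1 as follows: 1-carboxyethyl in place of 1-carboxypropyl on an aromatic carbon. The closest measured neighbour is compound 2, which also carries a 1-carboxyethyl group and gives 15 10^-6 cm/s. Since compound 1 and compound 2 lie within the scatter of each other, the expected step in this assay from compound 1 to compound 4 is none beyond the scatter, estimated as a 1.2-fold lower number from compound 1 to compound 4 (0.08 log units; within the scatter). Compound 4 is therefore expected to give about 14 10^-6 cm/s in this assay, within a range of 7 10^-6 cm/s to 26 10^-6 cm/s.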

Compound 4, apparent permeability: 5.2 10^-6 cm/s
Beside the measured number, compound 4's estimate is 2.7-fold (0.43 log units) above it; measured number below the stated range.
By their numbers in this assay, from the lowest: compound 3; then compound 4; then compounds 2 and 1 (each within the scatter of the next).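

In this assay, for the compounds shown here, replacing 1-carboxypropyl with 1-carboxyethyl gives a 3.3-fold lower number from compound 1 to compound 4 (0.51 log units; beyond the scatter) and provides the first single-place step, showing that this aromatic carbon is sensitive to a change confined to the side chain while the carboxylic acid is retained. The entering group also brings a defined stereocentre, so this one step combines the shorter chain and the defined stereochemistry and cannot assign the drop to either. No measurement shown here gives a cause for the step.

The opposite stereoisomer of the 1-carboxyethyl compound would separate those two contributions. On these data alone, whether the trend continues with a longer chain such as 1-carboxybutyl, or holds when a primary amide replaces the carboxylic acid, remains open.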